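Swapping Phenyl for tert-Butyl on the Ring Nitrogen

The compounds below may be only part of what the source reports. "The series", "measured", "known", "first", "only" and "open" are said of these compounds alone.

Compound 1 `Cc1cc(C)cc(NC(=O)Nc2cc(C(C)(C)C)nn2-c2ccccc2)c1`: 0.7 degrees C
Compound 2 `CC(C)(C)c1cc(NC(=O)Nc2ccc(F)c(F)c2)n(-c2ccccc2)n1`: 2.2 degrees C
Compound 3 `CC(C)(C)c1cc(NC(=O)Nc2cc(F)cc(F)c2)n(-c2ccccc2)n1`: 2.7 degrees C

In an assay on isolated protein for inhibition of Ephrin type-A receptor 2 (Homo sapiens), read by thermal shift assay, tested at 10 uM (a lower number here means that the compound stabilises the target less, a higher number that the compound stabilises the target more against heat), compound 3 stands highest of the three numbers shown. Its gap to the nearest number is within the scatter: a number 0.50 degrees C higher from compound 2 to compound 3 (within the scatter). Its gap to the furthest is beyond it: a number 2.0 degrees C higher from compound 1 to compound 3 (beyond the scatter). The third measured step is also modest: a number 1.5 degrees C higher from compound 1 to compound 2 (beyond the scatter).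

Compound 4 `CC(C)(C)c1cc(NC(=O)Nc2cc(F)cc(F)c2)n(C(C)(C)C)n1` differs from compound 3 in one place: tert-butyl in place of phenyl on an aromatic nitrogen. Within the data shown here, all three measured steps change only the aryl group on the amide-type nitrogen; none alters the group on the aromatic nitrogen, so no measured step bears directly on this change. The size and direction of the step in this assay are therefore open, and the expectation rests only on the narrow spread of the three measured values. The step is expected to be small, a number 0.90 degrees C lower from compound 3 to compound 4 (within the scatter), with wide uncertainty. Compound 4 is estimated at 1.8 degrees C, within a range from 0 degrees C to 3.5 degrees C.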

Compound 4, shift of the target's melting temperature: 0 degrees C
For compound 4 the middle estimate is 1.8 degrees C above the measured one, within the range that was stated.
By their numbers in this assay, from the lowest: compounds 4 and 1 (each within the scatter of the next); then compounds 2 and 3 (each within the scatter of the next).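

With 3,5-difluorophenyl held on the amide-type nitrogen, tert-butyl in place of phenyl on the aromatic nitrogen gives a number 2.7 degrees C lower from compound 3 to compound 4 (beyond the scatter) in this assay. Among these compounds, the earlier compounds varied only the aryl group on the amide-type nitrogen, so this is the first sign that the group on the aromatic nitrogen also affects the read-out, and in this pair the stabilisation seen with phenyl is absent with tert-butyl, as compound 4 gives 0 degrees C. No measurement at hand speaks to the reason for this step.

The compounds shown leave open whether a cyclohexyl or pyridyl group on the aromatic nitrogen would behave like phenyl or like tert-butyl. They also leave open whether the same change would have a similar effect with 3,4-difluorophenyl or 3,5-dimethylphenyl on the amide-type nitrogen.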